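Aryl swap on the ketone of compound 1

The source may hold more compounds than are shown below. What is called first, only, known or untested is meant among the compounds shown, and "the series" means these compounds.

Measured so far in a functional assay on DLA cells (Mus musculus) for cytotoxicity, read by trypan blue exclusion, with a stated time of 48 h; on this read-out higher numbers stand for weaker inhibition and lower numbers for stronger inhibition:
compound 1 `Cc1ccc(C(=O)c2ccc(OCC(=O)Nc3nc(-c4ccccc4)cs3)c(C)c2)cc1` gives 25000 nM
compound 2 `COc1ccc(-c2csc(NC(=O)COc3ccc(C(=O)c4ccc(C)cc4)cc3C)n2)cc1` gives 16000 nM

Compound 1 has the highest of the two numbers; its nearest neighbour is compound 2, and the step of a 1.6-fold lower number from compound 1 to compound 2 (0.19 log units; within the scatter) stays within the scatter, so the two values cannot be put in any order.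

Compound 3 `Cc1cc(C(=O)c2ccccc2F)ccc1OCC(=O)Nc1nc(-c2ccccc2)cs1` is not yet measured. It differs from compound 1 by 2-fluorophenyl in place of 4-methylphenyl on a carbonyl carbon.

Among the measured compounds shown here, no measured step touches this part of the series: the only step, a 1.6-fold lower number from compound 1 to compound 2 (0.19 log units; within the scatter), concerns a methoxy on an aromatic carbon elsewhere and was itself within the scatter. For compound 3 the working expectation is therefore a step of no change at the digits printed from compound 1 to compound 3 (within the scatter) that stays within the scatter, in no firm direction. Compound 3 is estimated at 25000 nM, with a range from 10000 nM to 60000 nM in this assay.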

Compound 3, half-maximal inhibitory concentration: 13700 nM
The estimate for compound 3 lay 1.8-fold (0.26 log units) above the measured number, within the range that was stated.
By their numbers in this assay, from the lowest: compounds 3, 2 and 1 (each within the scatter of the next).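

The carbonyl carbon now has its first reading in this assay: the step is a 1.8-fold lower number from compound 1 to compound 3 (0.26 log units; within the scatter) for 2-fluorophenyl in place of 4-methylphenyl. The two groups match in the counts available, at 7 heavy atoms and one six-membered aromatic ring of carbon only, so this exchange of one aryl group for another gives no reading that can be placed in any order. No supporting measurement is available to interpret this step.

Still open, on these data alone, is whether any group on this carbonyl carbon can move the number beyond the scatter, for example an aliphatic amine, a carboxylic acid or a longer chain in place of the aryl ring. Also open, as far as these compounds go, is how 2-fluorophenyl on the carbonyl carbon would read alongside the methoxy of compound 2.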